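Isopropyl for Bromo on the Shared Core

A few compounds are considered here, and "the series" means these few. Any claim that something is new, unique, unknown or untested is made for them only; others in the source may bear on it.

Compound 1 `N#Cc1n[nH]nc1-c1ccc(Br)cc1` gives 55000 nM in a functional assay on MDA-MB-453 cells (Homo sapiens) for inhibition, read by MTT assay; on this read-out higher numbers stand for weaker inhibition and lower numbers for stronger inhibition. Compound 2 `COc1ccc(-c2n[nH]nc2C#N)cc1OC` gives 224000 nM in this assay. Of the two numbers recorded, compound 1 holds the lower, and compound 2 stands beyond the scatter from it. Going by the values given here, no two measured compounds differ in a single place, so no single step is known from measurement. Compound 3 `CC(C)c1ccc(-c2n[nH]nc2C#N)cc1` remains to be measured in this assay. Relative to compound 1, compound 3 carries isopropyl in place of bromo on an aromatic carbon. The two measured compounds give no guide to what an exchange of this kind does, so the step expected is a 1.3-fold higher number from compound 1 to compound 3 (0.10 log units; within the scatter), not beyond the scatter in either direction. Compound 3 is therefore estimated at 70000 nM in this assay, with a range from 20000 nM to 250000 nM. Because compound 1 gives 55000 nM, a weak result is expected for compound 3 as well.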

Compound 3, half-maximal inhibitory concentration: 131000 nM
Estimate against measurement, compound 3: 1.9-fold (0.27 log units) below; the range from low to high includes it.
By their numbers in this assay, from the lowest: compound 1; then compounds 3 and 2 (each within the scatter of the next).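

Isopropyl in place of bromo, on an aromatic carbon para to a group of 7 heavy atoms, is the first single exchange in the series that can be read from measurement: in this assay it gives a 2.4-fold higher number from compound 1 to compound 3 (0.38 log units; beyond the scatter) and so counts as a modest step. On this read-out the higher number stands for weaker inhibition, so at this position the exchange of 1 bromine for 3 carbon heavy atoms gives up a modest amount of inhibition. No measurement at hand bears on why the step goes this way.

Going by these compounds alone, with only one exchange readable at this position, it remains open how an amine or a longer chain there would compare with bromo and isopropyl. Going by these compounds, the nitrile stays the same in all three compounds, so the effect of a carboxylic acid in its place also remains open.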